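From hydroxy to trifluoromethoxy on compound 2

The source may report more compounds than this note shows. Statements on the series, on what has been measured and on what is new or still open speak of the compounds shown alone.

In a functional assay on HCT-116 cells (Homo sapiens) for inhibition (a lower number here means a stronger inhibitor, a higher number a weaker inhibitor), compound 1 (`COCCOc1cc(/C=C\c2ccc3ccccc3c2)ccc1OC`) gives 2990 nM. Compound 2 (`Oc1ccc(/C=C/c2ccc3ccccc3c2)cc1`) gives 4060 nM, which lies within the usual scatter of the value for compound 1. Compound 3 (`FC(F)(F)Oc1ccc(/C=C/c2ccc3ccccc3c2)cc1`) differs from compound 2 by trifluoromethyl in place of hydrogen on an oxygen on an aromatic ring, with trifluoromethyl in place of hydrogen on an oxygen on an aromatic ring. Among the measured compounds shown here, no measured pair of compounds shows this change or any other single change. The expected 1.4-fold higher number from compound 2 to compound 3 (0.13 log units; within the scatter) in this assay stays within the scatter, leaning slightly towards a weaker inhibitor. Compound 3 is estimated at 5500 nM, with an expected range of 1800 nM to 17000 nM.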

Compound 3, half-maximal inhibitory concentration: > 5000 nM
Compound 3: no number, only a limit (the forecaster's own chance of this, stated with the estimate: 15%); the middle value does not contradict the limit.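

In this assay compound 3 carries only a limit of the assay, not a number: > 5000 nM. Trifluoromethyl in place of hydrogen on the oxygen on the aromatic ring gives the only single-change step shown, an at least 1.2-fold higher number from compound 2 to compound 3 (0.09 log units; that floor lies within the scatter), so this change at this position yields no stronger inhibitor, although the floor of the step lies within the scatter. The true size of the step stays unknown because compound 3 rests on a limit: the limit of > 5000 nM in this assay, at which 1 of the 3 values shown sits.

The compounds shown leave open how an amine or a carboxylic acid in place of hydroxy would read in this assay. From the compounds shown here alone, a longer chain on this oxygen also remains open.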